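Removing the 2-hydroxyethyl group from compound 3

The compounds below may be only part of what the source reports. "The series", "measured", "known", "first", "only" and "open" are said of these compounds alone.

Among the compounds with values here, compound 3 (`COc1ccc(C(c2ccc(OCCO)cc2)c2cccc3ccccc23)c(OC)c1OC`) gives 16600 nM in a functional assay on THP-1 cells (Homo sapiens) for inhibition, read by sulforhodamine B assay, with a stated time of 48 h (on this read-out higher numbers stand for weaker inhibition and lower numbers for stronger inhibition), and stands at the high end of the three numbers so far, within the scatter of compound 1 (`COc1ccc(C(c2ccc(OC(C)CN(C)C)cc2)c2cccc3ccccc23)c(OC)c1OC`), which gives 15000 nM on the same read-out. Compound 2 (`COc1ccc(C(O)(Cc2ccc(F)cc2)c2cccc3ccccc23)c(OC)c1OC`) gives 5860 nM and lies lower than compound 3, beyond the scatter. It differs from compound 3 in more than one place, however, so it offers no clean comparison here.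

The next structure is compound 4 (`COc1ccc(C(c2ccc(O)cc2)c2cccc3ccccc23)c(OC)c1OC`). The change is hydrogen in place of 2-hydroxyethyl on an oxygen on an aromatic ring and reads as hydrogen in place of 2-hydroxyethyl on an oxygen on an aromatic ring, or 4-(2-hydroxyethoxy)phenyl to 4-hydroxyphenyl.

Within the data shown here, only one measured step bears on this oxygen: a 1.1-fold higher number from compound 1 to compound 3 (0.04 log units; within the scatter) for 2-hydroxyethyl in place of 1-((dimethylamino)methyl)ethyl. Among the measured compounds shown here, that step exchanges one group for another, and no measured compound yet shows the free hydroxy, so the guidance is limited. Given a 1.1-fold higher number from compound 1 to compound 3 (0.04 log units; within the scatter) at that oxygen, no step beyond the scatter is expected in this assay and no firm direction can be assigned. The estimate corresponds to an expected 1.3-fold lower number from compound 3 to compound 4 (0.11 log units; within the scatter) and stays within the scatter. Compound 4 is expected at 13000 nM with an estimated range of 6000 nM to 28000 nM.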

Compound 4, half-maximal inhibitory concentration: 9450 nM
Beside the measured number, compound 4's estimate is 1.4-fold (0.14 log units) above it; the range from low to high includes it.
By their numbers in this assay, from the lowest: compounds 2, 4, 1 and 3 (each within the scatter of the next, the first and the last beyond it).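

In this assay, within the data shown here, the oxygen on the aromatic ring now carries three different substituents, and compound 4 is the first case with hydrogen there. The step reads a 1.8-fold lower number from compound 3 to compound 4 (0.24 log units; within the scatter) for hydrogen in place of 2-hydroxyethyl, and a 1.6-fold lower number from compound 1 to compound 4 (0.20 log units; within the scatter) for hydrogen in place of 1-((dimethylamino)methyl)ethyl. Both steps lie within the scatter, as does the earlier step at this oxygen, so across compounds 1, 3 and 4 neither removing the substituent altogether nor exchanging a chain that ends in a hydroxy for one that ends in a dimethylamino gives a readable change, and no outside data bear on this result.

On these data alone, whether a methyl, a carboxylic acid or a longer chain ending in a morpholine on this oxygen would also stay within the scatter remains open. Compound 2 differs from compounds 1, 3 and 4 in more than one place, so its steps to them cannot be read, and which of its differences matters in this series is unresolved.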